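Trading trifluoromethyl for fluoro in a two-compound series

A few compounds are considered here, and "the series" means these few. Any claim that something is new, unique, unknown or untested is made for them only; others in the source may bear on it.

Of the compounds shown here, two have been measured so far in a functional assay on MDA-MB-231 cells (Homo sapiens) for antiproliferative activity, read by MTT assay, with a stated time of 72 h; a lower number here means a stronger inhibitor, a higher number a weaker inhibitor. Compound 1 `O=S1(=O)C=Cc2ccc(Nc3cccc(C(F)(F)F)c3)cc21` gives 1310 nM, and compound 2 `O=S1(=O)C=Cc2cccc(Nc3cccc(C(F)(F)F)c3)c21` gives 680 nM. These two values lie within the usual scatter of repeated measurements, so the numbers do not separate compound 2 from compound 1.

The next compound to be tested is compound 3 `O=S1(=O)C=Cc2cccc(Nc3cccc(F)c3)c21`, which keeps the rest of compound 2 and alters a single group: fluoro in place of trifluoromethyl on an aromatic carbon. Among the measured compounds shown here, no measured pair shows this kind of swap, so the forecast is a judgement with wide margins rather than a reading from earlier data. A modest move towards a weaker inhibitor seems most likely, with the number rising a little beyond the scatter, though no change at all would not be surprising. The estimated step is a 2.2-fold higher number from compound 2 to compound 3 (0.34 log units; beyond the scatter). For compound 3 the expected value in this assay is 1500 nM, with an estimated range from 500 nM to 5000 nM.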

Compound 3, half-maximal inhibitory concentration: 1910 nM
Compound 3: the middle estimate sits 1.3-fold (0.10 log units) below what was measured; measured number inside the range.
By their numbers in this assay, from the lowest: compounds 2, 1 and 3 (each within the scatter of the next, the first and the last beyond it).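

In this assay, the step from trifluoromethyl to fluoro on this aromatic carbon is a 2.8-fold higher number from compound 2 to compound 3 (0.45 log units; beyond the scatter). This is the first change shown here that separates two compounds by more than the scatter of repeated measurements, so the group at this place does affect the read-out, with trifluoromethyl giving the stronger inhibitor of this pair. The change removes a group of 4 heavy atoms and puts one of 1 heavy atom in its place, neither with a hydrogen-bond donor or acceptor, and the effect is modest, since compound 3 still gives 1910 nM and the activity is far from lost. No measurement available here explains why the number rises.

As far as these compounds go, a single swap gives two points and no trend, so it remains open where groups such as chloro, methyl, methoxy or a plain hydrogen on the same carbon would fall relative to this pair. From the compounds shown here alone, it is also open whether the same swap made on compound 1 would give a step of similar size, or whether this step belongs to the arrangement found in compound 2.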